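Iodo in place of butoxy on compound 2

The source may report more compounds than this note shows. Statements on the series, on what has been measured and on what is new or still open speak of the compounds shown alone.

Of the compounds shown here, two on the shared core have values so far in a functional assay on HFF cells (Homo sapiens) for cytotoxicity (a higher number here means a weaker inhibitor, a lower number a stronger inhibitor), on these notes. Compound 1 (`CC(=O)OC1C(CBr)OC(n2c(Cl)nc3cc(Cl)c(Cl)cc32)C1OC(C)=O`) gives 32000 nM there and compound 2 (`CCCCOC[C@H]1OC(n2c(Cl)nc3cc(Cl)c(Cl)cc32)[C@H](O)[C@@H]1O`) gives 32000 nM as well, so compound 2 stands level with compound 1 within the scatter. Compound 3 (`O[C@@H]1[C@@H](CI)OC(n2c(Cl)nc3cc(Cl)c(Cl)cc32)[C@@H]1O`) departs from compound 2 in one place. The change is iodo in place of butoxy on a saturated chain carbon bound to a saturated ring carbon on a saturated chain carbon bound to a saturated ring carbon, the same difference reading butoxymethyl to iodomethyl. Within the data shown here, no measured pair isolates this change, so its size has no direct precedent. In this assay no shift beyond the scatter is expected, in either direction. The expected step of a 1.3-fold lower number from compound 2 to compound 3 (0.11 log units; within the scatter) is accordingly small. Compound 3 is estimated at 25000 nM within an expected range of 8000 nM to 80000 nM in this read-out.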

Compound 3, half-maximal inhibitory concentration: 32000 nM
Beside the measured number, compound 3's estimate is 1.3-fold (0.11 log units) below it, within the range that was stated.
By their numbers in this assay, from the lowest: compounds 1, 2 and 3 (each within the scatter of the next).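

Under this assay iodo in place of butoxy on a saturated chain carbon bound to a saturated ring carbon gives no change at the digits printed from compound 2 to compound 3 (within the scatter) and is the only step that can be read at this position. Among these compounds, it shows that this place can carry either butoxy, with its 5 heavy atoms including an oxygen, or a single iodine without any shift beyond the scatter in this read-out, which the earlier compounds, linked by no one-place step, could not show. Nothing on hand bears on why the number holds.

As far as these compounds go, whether an amine, a carboxylic acid or a chain longer than butoxy at the same place would also leave the number unmoved stays open. With only these two groups compared here, the tolerance of this position to other kinds of substituent also remains undefined.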